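Sulfonamide series against mitochondrial malate dehydrogenase: working notes

The source may hold more compounds than are shown below. What is called first, only, known or untested is meant among the compounds shown, and "the series" means these compounds.

Compound 1 `O=S(=O)(Nc1ccc(-c2nc3ccccc3o2)cc1)c1cccc(C(F)(F)F)c1` and compound 2 `COc1ccc(Cl)cc1S(=O)(=O)Nc1ccc(-c2nc3ccccc3o2)cc1` share one core and differ only in the group on the sulfonyl sulfur. In an assay on isolated protein for inhibition of malate dehydrogenase, mitochondrial (Sus scrofa), with stated times of 45 min and 30 min (a lower number here means a stronger inhibitor, a higher number a weaker inhibitor), compound 1 gives > 63000 nM, which is a limit of the assay and not a number. In this assay compound 2 gives > 63000 nM, again a limit rather than a measured number. Among the compounds with values here, compound 2 therefore stands at the limit, and the one other value shown sits at the same place: the limit of > 63000 nM in this assay, at which 2 of the 2 values shown sit. Within the data shown here, no step between measured compounds can be read, since both values are limits.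

Compound 3 `Cc1cccc(S(=O)(=O)Nc2ccc(-c3nc4ccccc4o3)cc2)c1` carries 3-methylphenyl in place of 5-chloro-2-methoxyphenyl on a sulfonyl sulfur. Given that both known values rest at the limit of > 63000 nM in this assay, at which 2 of the 2 values shown sit, the step from compound 2 to compound 3 is expected to be a step that the limit leaves unreadable from compound 2 to compound 3, none beyond the scatter in either direction. Compound 3 is accordingly estimated at 100000 nM, with a range from 30000 nM to 400000 nM, and most likely reported once more as a limit.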

Compound 3, half-maximal inhibitory concentration: > 63000 nM
Compound 3: a limit, no number (the forecaster's own chance of this, stated with the estimate: 85%); the middle value does not contradict the limit.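

Within the data shown here, no step from compound 3 to compound 1 or compound 2 can be read, since each value is a limit of the assay and not a number: the limit of > 63000 nM in this assay, at which 3 of the 3 values shown sit.

In this assay the compounds shown leave open whether any group on the sulfonyl sulfur of the shared core gives a measurable value.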